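The source may report more compounds than this note shows. Statements on the series, on what has been measured and on what is new or still open speak of the compounds shown alone.

Compound 1 `CCOC(=O)c1c(C)oc2nc(N3CCN(c4ccccc4)CC3)ccc12`: "not determined" (no result reported)
Compound 2 `CNC(=O)c1c(C(C)C)oc2nc(N3CCCC3)ccc12`: "not determined" (no result reported)
Compound 3 `CCOC(=O)c1c(C(C)C)oc2nc(N3CCCC3)ccc12`: > 330000 nM

In an ADME assay on MRC5 cells (Homo sapiens) for cytotoxicity, read by fluorescence and resazurin assay, with a stated time of 24 h (on this read-out higher numbers stand for weaker inhibition and lower numbers for stronger inhibition), compound 3 gives > 330000 nM, which is a limit of the assay and not a number. Among the measured compounds shown here, it is the only one of the three compounds with a reported result, and no single number is available for any of them.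

Compound 4 `CCOC(=O)c1c(-c2ccccc2)oc2nc(N3CCCC3)ccc12` carries phenyl in place of isopropyl on an aromatic carbon, (phenyl in place of isopropyl on an aromatic carbon). For the measured compounds named here, no measured pair of compounds differs in one place, so the expectation rests on the structural change alone. A modest move toward stronger inhibition in this assay is expected, an at least 1.6-fold lower number from compound 3 to compound 4 (0.21 log units; that floor lies within the scatter). Compound 4 is estimated at 200000 nM, with an expected range of 70000 nM to 330000 nM.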

Compound 4, half-maximal inhibitory concentration: > 297000 nM
Compound 4 gave a limit, no number; the forecaster's own chance of this, stated with the estimate: 60%; middle value at least 1.4-fold (0.17 log units) away from the limit.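

The step between compound 3 and compound 4 cannot be read, as each gives only a limit and not a number in this assay. The compounds shown leave open whether phenyl and isopropyl differ at all in this assay.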